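The source may hold more compounds than are shown below. What is called first, only, known or untested is meant among the compounds shown, and "the series" means these compounds.

Measured compounds in an assay on cells for displacement of a labelled ligand from Orexin/Hypocretin receptor type 1 (Homo sapiens), read by scintillation counting, with stated times of 10 min and 90 min, tested at 10 uM; a lower number here means less inhibition, a higher number more inhibition at the concentration tested (going by the name of the read-out):
- compound 1, `COC(=O)Cc1ccc2ccc(C(=O)c3ccc(C(F)(F)F)cc3)c-2cc1`: -30.4%
- compound 2, `O=C(O)Cc1ccc2ccc(C(=O)c3ccc(C(F)(F)F)cc3)c-2cc1`: 8.6%

Compound 2 stands highest of the two numbers in this assay; compound 1 is the nearest and lies lower, the gap being beyond the scatter. Among the compounds with values here, the only measured step is a number 39 percentage points higher from compound 1 to compound 2 (beyond the scatter), a hydrogen in place of methyl on an oxygen next to a carbonyl group. Both values nevertheless sit at or below zero inhibition, so neither compound shows appreciable displacement at the concentration tested.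

Compound 3, `Cc1ccc2ccc(C(=O)c3ccc(C(F)(F)F)cc3)c-2cc1`, is the next compound for this assay. It differs from compound 2 by hydrogen in place of carboxy on a saturated chain carbon bound to an aromatic carbon. Within the data shown here, the measured step from compound 1 to compound 2 touches the same chain but keeps the carboxy in one form or another; no measured step removes it, so it bears on the new change only loosely. With both measured numbers near zero, a step of no clear direction beyond the scatter is expected. The estimate for compound 3 in this assay is 2%, with a range from -25% to 30%, which is expected to mean a step of a number 6.6 percentage points lower from compound 2 to compound 3 (within the scatter).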

Compound 3, a percentage reported as inhibition, at one concentration (the size of the read-out at that concentration, not a potency): 38.3%
For compound 3 the middle estimate is 36.3 percentage points below the measured one; the measured number lies above the stated range.
By their numbers in this assay, from the lowest: compound 1; then compound 2; then compound 3.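

In this assay, within the data shown here, the step of a number 29.7 percentage points higher from compound 2 to compound 3 (beyond the scatter) is the first change to act on the chain itself rather than on the ester or acid form of its end, and it shows that the carboxy is not needed for inhibition at the concentration tested. The step of a number 68.7 percentage points higher from compound 1 to compound 3 (beyond the scatter), with methoxycarbonyl leaving the same saturated chain carbon bound to an aromatic carbon, points the same way, and compound 3, at 38.3%, stands beyond the scatter above both compounds that carry a carbonyl group on this chain, so within these three compounds the plain methyl gives the highest number. Nothing measured here accounts for the size of these steps or for the lower number of the ester compared with the acid.

The compounds shown leave open whether the rise follows the loss of the carbonyl group or depends on the short methyl itself, which an aminomethyl, a hydroxymethyl or a longer alkyl chain at this place could help to separate. They also leave open how potent compound 3 is, as a percentage at one concentration is not a potency.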